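The compounds below may be only part of what the source reports. "The series", "measured", "known", "first", "only" and "open" are said of these compounds alone.

Three compounds share one core and were measured in a functional assay for inhibition, with Homo sapiens as the target; a higher number here means a weaker inhibitor, a lower number a stronger inhibitor.

Compound 1 `CCCc1ncn2c(Nc3cc[nH]n3)nccc12` gives > 48000 nM, a limit of this assay rather than a number.
Compound 2 `Cc1ncn2c(Nc3cc[nH]n3)nccc12` gives 57000 nM.
Compound 3 `CC(C)c1ncn2c(Nc3cc[nH]n3)nccc12` gives > 48000 nM, again a limit and not a number.

Among the compounds with values here, compound 2 therefore holds the only number in this set; the other two values sit at the limit, as the limit of > 48000 nM in this assay, at which 2 of the 3 values shown sit, shows. None of the steps among the measured compounds can be read: a step that the limit leaves unreadable from compound 1 to compound 2, a step that the limit leaves unreadable from compound 2 to compound 3 and a step that the two limits leave unreadable from compound 1 to compound 3 all stay hidden behind the limit. What the three values do show is that every measured compound is a weak inhibitor in this assay, whatever the group on that aromatic carbon.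

Compound 4 `Cc1nc(C)n2c(Nc3cc[nH]n3)nccc12` differs from compound 2 in one place: methyl in place of hydrogen on an aromatic carbon. Within the data shown here, no measured step bears directly on this change, and the steps that touch the neighbouring position give no readable size. The expectation for compound 4 is accordingly a step of a 1.0-fold lower number from compound 2 to compound 4 (0.02 log units; within the scatter) from compound 2, that is, none beyond the scatter, with a fair chance that this assay returns only a limit. The estimate for compound 4 is 55000 nM, within a range from 25000 nM to 120000 nM.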

Compound 4, half-maximal inhibitory concentration: 53000 nM
Compound 4: the middle estimate sits 1.0-fold (0.02 log units) above what was measured; the measured number falls inside the stated range.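

In this assay, within the data shown here, methyl in place of hydrogen on the aromatic carbon between two ring nitrogen atoms gives a 1.1-fold lower number from compound 2 to compound 4 (0.03 log units; within the scatter), the first step in this set that can be read. The earlier steps shown here all concern the group on the ring atom that bears a methyl group in compound 2, and none of them can be read, so this is the only measured size for a change on the shared core. A single methyl on this carbon therefore makes no difference beyond the scatter, and compound 2 and compound 4 both remain weak inhibitors, with numbers of the same order as the limit that holds compound 1 and compound 3: the limit of > 48000 nM in this assay, at which 2 of the 4 values shown sit.

The compounds shown leave open whether anything other than methyl on this carbon, such as an amine, a carboxylic acid or a longer chain, would give a number beyond the scatter. They also leave open whether methyl on this carbon would give a similar step with propyl or isopropyl in place of the methyl group two ring bonds away.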